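This account rests on a few compounds, and the source may have more. Where it says the series, first, only, none or still open, it means among the compounds named here.

Measured compounds:
- Compound 1, `CN1CCN(c2ccc(Nc3nc(-c4cccc(NC(=O)c5cccc(F)c5)c4)sc3C(=O)O)cc2)CC1`, gives 76.3%.
- Compound 2, `CN1CCN(c2ccc(Nc3nc(-c4cccc(NC(=O)c5ccccc5F)c4)sc3C(=O)O)cc2)CC1`, gives 86.9%.
- Compound 3, `CN1CCN(c2ccc(Nc3nc(-c4cccc(NC(=O)c5cccc(F)c5)c4)sc3C(N)=O)cc2)CC1`, gives 2.78%.

All three were tested in a functional assay on Raji cells (Homo sapiens) for antiproliferative activity, read by CCK-8 assay, with a stated time of 72 h, tested at 40 uM; a higher number here means more inhibition at the concentration tested (going by the name of the read-out), a lower number less inhibition. Compound 1 and compound 2 share one core and differ only in a single group: 2-fluorophenyl in place of 3-fluorophenyl on a carbonyl carbon. That change made a step of a number 10.6 percentage points higher from compound 1 to compound 2 (beyond the scatter). Compound 3 carries the same fluorophenyl group as compound 1 but a different core: amino in place of hydroxy on a carbonyl carbon. This change in the core made a step of a number 73.5 percentage points lower from compound 1 to compound 3 (beyond the scatter), leaving compound 3 with the lowest number of the three and far from both others.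

Compound 4, `CN1CCN(c2ccc(Nc3nc(-c4cccc(NC(=O)c5ccccc5F)c4)sc3C(N)=O)cc2)CC1`, has not yet been measured. It stands to compound 3 exactly as compound 2 stands to compound 1: 2-fluorophenyl in place of 3-fluorophenyl on a carbonyl carbon. The place where the change is made is described in the same words for both pairs, so it is the same change, now made on the core of compound 3 rather than on the core of compound 1.

On the core of compound 1 this change brought a modest rise. As far as these compounds go, whether it does the same on the core of compound 3 is unknown; compound 3 starts so low that a rise of similar size would still leave compound 4 weak. The expectation for compound 4 is a step of a number 6.2 percentage points higher from compound 3 to compound 4 (within the scatter), resting on the step of a number 10.6 percentage points higher from compound 1 to compound 2 (beyond the scatter) and the low starting number of compound 3. Compound 4 is therefore estimated at 9%, with a range from 0% to 28%.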

Compound 4, a percentage reported as inhibition, at one concentration (the size of the read-out at that concentration, not a potency): 97.3%
Estimate against measurement, compound 4: 88.3 percentage points below; the measured number lies above the stated range.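

In this assay, 2-fluorophenyl in place of 3-fluorophenyl on a carbonyl carbon gives a number 94.5 percentage points higher from compound 3 to compound 4 (beyond the scatter), a far larger rise than the same change gives on the core of compound 1: the same change on two cores in this assay, a number 10.6 percentage points higher (beyond the scatter) from compound 1 to compound 2 and a number 94.5 percentage points higher (beyond the scatter) from compound 3 to compound 4, 83.9 percentage points apart, beyond the scatter of two such steps

Seen from the other direction, amino in place of hydroxy on a carbonyl carbon gives a number 10.4 percentage points higher from compound 2 to compound 4 (beyond the scatter), whereas with the 3-fluorophenyl group the same swap brought a steep fall: the same change on two cores in this assay, a number 73.5 percentage points lower (beyond the scatter) from compound 1 to compound 3 and a number 10.4 percentage points higher (beyond the scatter) from compound 2 to compound 4, 83.9 percentage points apart, beyond the scatter of two such steps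

These four compounds therefore show that the size of a step made on one core cannot be carried over to the other core, and that the effect of each change depends on the group present at the other place, but they do not show why this happens or whether it holds beyond these four compounds.

The compounds shown leave open whether a plain phenyl group on the carbonyl carbon, or methoxy in place of hydroxy or amino on the other carbonyl carbon, would follow the same interdependence. They also leave open how these compounds compare across a range of concentrations, since each number here is a reading at a single concentration and not a potency.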